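Changing the benzyl group of compound 2

A few compounds are considered here, and "the series" means these few. Any claim that something is new, unique, unknown or untested is made for them only; others in the source may bear on it.

Compound 1 `Fc1ccccc1CSc1nnc(-c2cnccn2)o1`: 12500 nM
Compound 2 `Clc1ccccc1CSc1nnc(-c2cnccn2)n1-c1ccccc1`: 18800 nM

Both compounds were tested in a functional assay on HepG2 cells (Homo sapiens) for antiproliferative activity, read by MTT assay, with a stated time of 48 h; a lower number here means a stronger inhibitor, a higher number a weaker inhibitor. Their two values lie within the usual scatter of each other, so the numbers do not separate compound 2 from compound 1.

Compound 3 `Fc1cccc(F)c1CSc1nnc(-c2cnccn2)n1-c1ccccc1` keeps the rest of compound 2 but carries 2,6-difluorophenyl in place of 2-chlorophenyl on a saturated chain carbon bound to a sulfur.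

Among the measured compounds shown here, no two measured compounds differ in just one place, so the data offer no direct guide to this change. The best anchor is compound 2 at 18800 nM. The expected change in this assay is none beyond the scatter, with no firm direction. The estimated step is a 1.2-fold lower number from compound 2 to compound 3 (0.07 log units; within the scatter). For compound 3 the estimated value is 16000 nM, with an expected range from 7000 nM to 40000 nM.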

Compound 3, half-maximal inhibitory concentration: 22600 nM
Beside the measured number, compound 3's estimate is 1.4-fold (0.15 log units) below it; the measured number falls inside the stated range.
By their numbers in this assay, from the lowest: compounds 1, 2 and 3 (each within the scatter of the next).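

In this assay, placing 2,6-difluorophenyl in place of 2-chlorophenyl on a saturated chain carbon bound to a sulfur gives a 1.2-fold higher number from compound 2 to compound 3 (0.08 log units; within the scatter). This is the first pair shown that differs in just one place, so it gives the first direct reading at this position: the measurement cannot tell these two groups apart. No measurement at hand gives a reason for this outcome.

Going by these compounds, both groups carry halogen atoms on a phenyl ring, so it remains open whether a plain benzyl group, an aminoethyl chain or a carboxylic acid at this position would give a number clearly different from compound 2. Compound 1 differs from compound 2 in more than one place, so its value cannot settle this question.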